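From compound 1 to compound 4: a new carbonyl substituent

The compounds below may be only part of what the source reports. "The series", "measured", "known", "first", "only" and "open" are said of these compounds alone.

Among the compounds with values here, in a functional assay on ID8 cells (Mus musculus) for antiproliferative activity (on this read-out higher numbers stand for weaker inhibition and lower numbers for stronger inhibition), compound 1 `O=C(Nc1ccc(O)c2c(=O)cc(-c3ccccc3Cl)oc12)c1ccc(Cl)c(Cl)c1` gives 13000 nM and compound 3 `O=c1cc(-c2ccccc2Cl)oc2c(N3CCCC3)ccc(O)c12` gives 9300 nM with the two values within the scatter of each other, so compound 1 stands level with the only other number. For compound 2 `O=C(Nc1c(O)cc(O)c2c(=O)cc(-c3ccccc3Cl)oc12)c1ccc(Cl)cc1` the entry reads "not determined" (no result reported).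

Compound 4 `C[C@H](NC(=O)OC(C)(C)C)C(=O)Nc1ccc(O)c2c(=O)cc(-c3ccccc3Cl)oc12` is still to be measured. It carries 1-((tert-butoxycarbonyl)amino)ethyl in place of 3,4-dichlorophenyl on a carbonyl carbon and keeps the rest of compound 1 unchanged. Within the data shown here, no measured step between compounds differing in one place is available to size this change. Compound 3 at 9300 nM has no such amide, yet it stays within the scatter of compound 1 at 13000 nM on the evidence of only these two numbers. No step beyond the scatter is therefore expected in this assay and neither direction is favoured. The estimated step of a 1.2-fold lower number from compound 1 to compound 4 (0.07 log units; within the scatter) is small but uncertain. For compound 4 the expected value is 11000 nM with an estimated range from 3500 nM to 35000 nM for repeat measurements.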

Compound 4, half-maximal inhibitory concentration: 9800 nM
Beside the measured number, compound 4's estimate is 1.1-fold (0.05 log units) above it; low and high end bracket the measured number.
By their numbers in this assay, from the lowest: compounds 3, 4 and 1 (each within the scatter of the next).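

In this assay, 1-((tert-butoxycarbonyl)amino)ethyl in place of 3,4-dichlorophenyl on a carbonyl carbon gives a 1.3-fold lower number from compound 1 to compound 4 (0.12 log units; within the scatter) and so no step beyond the scatter. Within the data shown here, this is the only measured step at this position, and it shows that the read-out holds its level when the six-membered aromatic ring leaves and a group with no ring, a hydrogen-bond donor, hydrogen-bond acceptors and a defined stereocentre enters. No measured property of either group is available to interpret this result.

Going by these compounds, whether a free primary amine in place of the tert-butoxycarbonyl-protected amine, or a carboxylic acid on the same chain, would move the number beyond the scatter remains open. The compounds shown also leave open whether the opposite configuration at the stereocentre would change the read-out.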